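A Fluorophenoxy Analogue Expected from a Thioether Precursor

A few compounds are considered here, and "the series" means these few. Any claim that something is new, unique, unknown or untested is made for them only; others in the source may bear on it.

Compound 1 `COc1cc(CNc2nc3cc(N)cc(N)c3nc2-c2ccccc2)cc(OC)c1OC` and compound 2 `COc1ccc(CNc2nc3cc(N)cc(N)c3nc2-c2ccccc2)cc1` share the core with compound 3 and compound 4. In a functional assay on OVCAR-5 cells (Homo sapiens) for inhibition, read by sulforhodamine B assay, with a stated time of 48 h (on this read-out lower numbers stand for stronger inhibition of growth and higher numbers for weaker inhibition of growth), compound 1 gives 21400 nM. Compound 2 gives 20900 nM in this assay. Compound 3 `COc1ccc(Sc2nc3cc(N)cc(N)c3nc2-c2ccccc2)cc1` carries a (4-methoxyphenyl)sulfanyl group. In this assay compound 3 gives only a limit, < 100000 nM, so its place among these numbers is known merely as a bound, as noted by the limit of < 100000 nM in this assay, at which 1 of the 3 values shown sits. Compound 4 `Nc1cc(N)c2nc(-c3ccccc3)c(Oc3ccc(F)cc3)nc2c1` has not been measured and differs from compound 3 by 4-fluorophenoxy in place of (4-methoxyphenyl)sulfanyl on an aromatic carbon. For the measured compounds named here, no measured step between compounds differing in one place exists, so the step in this assay can only be estimated and may run either way or stay within the scatter. Compound 4 is expected to give about 30000 nM, between 8000 nM and 100000 nM, an expected step that the limit leaves unreadable from compound 3 to compound 4.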

Compound 4, concentration for 50% growth inhibition: 20400 nM
The estimate for compound 4 lay 1.5-fold (0.17 log units) above the measured number; low and high end bracket the measured number.
By their numbers in this assay, from the lowest: compounds 4, 2 and 1 (each within the scatter of the next).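

No step from compound 3 to compound 4 can be read, because compound 3 has only a limit: the limit of < 100000 nM in this assay, at which 1 of the 4 values shown sits.

The compounds shown leave open whether 4-fluorophenoxy in place of (4-methoxyphenyl)sulfanyl changes growth inhibition at all in this assay.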